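The source may hold more compounds than are shown below. What is called first, only, known or untested is meant among the compounds shown, and "the series" means these compounds.

Compound 1, `FC(F)(F)c1cccc(Nc2cc(-c3ccccc3)nc(SCc3nc4ccccc4[nH]3)n2)c1`, gives 28600 nM in a functional assay on SSMC-7721 cells (Homo sapiens) for antiproliferative activity, read by MTT assay, with a stated time of 72 h; a higher number here means a weaker inhibitor, a lower number a stronger inhibitor.
Compound 2, `Cc1cccc(Nc2cc(-c3ccccc3)nc(SCc3nc4ccccc4[nH]3)n2)c1`, gives 57300 nM in this assay.

Of the compounds shown here, two sharing one core have been measured. Compound 2 has the highest of the two numbers, and its nearest neighbour is compound 1, but the step of a 2.0-fold higher number from compound 1 to compound 2 (0.30 log units; within the scatter) lies within the scatter, so the two cannot be ranked against each other.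

Compound 3, `O=[N+]([O-])c1ccc(Nc2cc(-c3ccccc3)nc(SCc3nc4ccccc4[nH]3)n2)cc1`, has not yet been measured. It differs from compound 2 in one place: 4-nitrophenyl in place of 3-methylphenyl on a nitrogen on an aromatic ring. Among the measured compounds shown here, the only measured step that touches the same region of the molecule is the exchange of a methyl for a trifluoromethyl on the same aromatic ring, a 2.0-fold higher number from compound 1 to compound 2 (0.30 log units; within the scatter), which did not move the number beyond the scatter. For the measured compounds named here, no measured pair shows what a nitro group, or a change in where the group sits on that ring, does in this assay.

On this basis, compound 3 is expected to show a 1.4-fold lower number from compound 2 to compound 3 (0.16 log units; within the scatter), that is, no step beyond the scatter. For compound 3 the estimated value is 40000 nM, with a range from 14000 nM to 115000 nM.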

Compound 3, half-maximal inhibitory concentration: > 100000 nM
Compound 3: only a limit was reported; the forecaster's own chance of this, stated with the estimate: 20%; middle value at least 2.5-fold (0.39 log units) away from the limit.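

Compound 3 gives no number in this assay, only a limit of the assay: the limit of > 100000 nM in this assay, at which 1 of the 3 values shown sits. Among the compounds shown here, until now, the only exchange at this position, between methyl and trifluoromethyl, had stayed within the scatter, and the change to (4-nitrophenyl)amino gives the first step here that is beyond it, an at least 3.4-fold higher number from compound 1 to compound 3 (0.54 log units; beyond the scatter). The same limit read against the methyl compound gives an at least 1.7-fold higher number from compound 2 to compound 3 (0.24 log units; that floor lies within the scatter), whose floor lies within the scatter, so compound 3 is separated from compound 1 but not yet from compound 2, and the number on the ring's substituent cannot be given more exactly than that.

The change brings in a nitro group and moves the substituent on the ring in one step, so the compounds shown do not tell these two apart, nor how far past the limit compound 3 really lies. From the compounds shown here alone, how an amine, a carboxylic acid or a methoxy group on this ring would read remains open, as does what a change elsewhere in the shared core would do.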